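Swapping a Hydroxyethyl Group for a Fluorophenyl Group

This account rests on a few compounds, and the source may have more. Where it says the series, first, only, none or still open, it means among the compounds named here.

compound 1, `CCCCCCCCc1cn([C@@H]2O[C@H](CO)[C@@H](O)[C@H]2O)nn1`, 56000 nM
compound 2, `CC(O)c1cn([C@@H]2O[C@H](CO)[C@@H](O)[C@H]2O)nn1`, > 200000 nM

Of the compounds shown here, two have been measured in a functional assay on L1210 cells (Mus musculus); a lower number here means a stronger inhibitor, a higher number a weaker inhibitor. Compound 1 `CCCCCCCCc1cn([C@@H]2O[C@H](CO)[C@@H](O)[C@H]2O)nn1` gives 56000 nM. Compound 2 `CC(O)c1cn([C@@H]2O[C@H](CO)[C@@H](O)[C@H]2O)nn1` reaches only the limit of the assay, > 200000 nM, so that no number stands for it; this is the limit of > 200000 nM in this assay, at which 1 of the 2 values shown sits. Within the data shown here, compound 2 therefore sits at the weak end of what the assay can report, and no measured step between the two compounds is at hand to serve as a guide. Compound 3 `OC[C@H]1O[C@@H](n2cc(-c3ccc(F)cc3)nn2)[C@H](O)[C@@H]1O` differs from compound 2 by 4-fluorophenyl in place of 1-hydroxyethyl on an aromatic carbon. Among the measured compounds shown here, with no measured step to lean on, the expected change from compound 2 to compound 3 is written down as a move beyond the scatter toward a measurable value, and an at least 2.5-fold lower number from compound 2 to compound 3 (0.39 log units; beyond the scatter) is the size expected for it. Compound 3 is estimated at 80000 nM, within 20000 nM to 300000 nM.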

Compound 3, half-maximal inhibitory concentration: 209000 nM
Beside the measured number, compound 3's estimate is 2.6-fold (0.42 log units) below it, within the range that was stated.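

In this assay, among these compounds, compound 2 has only the limit > 200000 nM and no number, so no step from it to compound 3 can be read. The compounds shown leave open how far 4-fluorophenyl in place of 1-hydroxyethyl on an aromatic carbon shifts the value.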